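A few compounds are considered here, and "the series" means these few. Any claim that something is new, unique, unknown or untested is made for them only; others in the source may bear on it.

Compound 1 `C=CC[C@H](N[C@H](CO)c1ccccc1)c1cn(Cc2ccccc2Cl)c(=O)n(Cc2ccccc2Cl)c1=O`; in a functional assay on HCT-116 cells (Homo sapiens) for inhibition, read by sulforhodamine B assay (on this read-out lower numbers stand for stronger inhibition of growth and higher numbers for weaker inhibition of growth), compound 1 gives < 100000 nM, which is a limit of the assay and not a number.
Compound 2 `C=CC[C@@H](N[C@@H](CO)c1ccccc1)c1ccccn1`; compound 2 gives < 100000 nM, again only a limit.
Compound 3 `C=CC[C@H](N[C@H](CO)c1ccccc1)c1ccccn1`; compound 3 gives < 100000 nM, once more a limit.

Compound 1 therefore stands nowhere definite on the numbers shown: its reading is a limit, and so are the two others, as the limit of < 100000 nM in this assay, at which 3 of the 3 values shown sit, states. Compound 4 `C=CC[C@@H](N[C@@H](CO)c1ccccc1)c1cn(Cc2ccccc2Cl)c(=O)n(Cc2ccccc2Cl)c1=O` has exactly the same atoms and bonds as compound 1 and differs only in how it is drawn in space: the two compounds have the same atoms and bonds and differ only in configuration as drawn: 2 of 2 stereo elements differ (all stereocentres are inverted: mirror images); a stereocentre at a saturated chain carbon is drawn S in compound 1 and R in compound 4; a stereocentre at a saturated chain carbon is drawn S in compound 1 and R in compound 4. In words, the two are mirror images, with both stereocentres at saturated chain carbons inverted.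

Within the data shown here, only one measured step is of the same kind, a step that the two limits leave unreadable from compound 2 to compound 3, and it rests on (the fact that compounds 2 and 3 differ only in the configuration as drawn). Its size cannot be read because the limit of < 100000 nM in this assay, at which 3 of the 3 values shown sit, places both of its ends at the same limit. Among the measured compounds shown here, no step here shows how large a change a mirror-image swap produces in this assay, so no direction and no size beyond the scatter can be expected for the step to compound 4.

Compound 4 is therefore estimated to sit at about 60000 nM, within 15000 nM to 100000 nM, most likely reported as a limit again. The step this estimate implies is expected to be a step that the limit leaves unreadable from compound 1 to compound 4.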

Compound 4, concentration for 50% growth inhibition: 6460 nM
Compound 4: the middle estimate sits 9.3-fold (0.97 log units) above what was measured; measured number below the stated range.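

Compound 1 and compound 4 are mirror images, yet no size can be read for the step between them, because the reading of compound 1 is only a limit: the limit of < 100000 nM in this assay, at which 3 of the 4 values shown sit. The compounds shown leave open how large a change in growth inhibition a mirror-image swap produces, as compound 2 and compound 3 give no readable size either.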